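A few compounds are considered here, and "the series" means these few. Any claim that something is new, unique, unknown or untested is made for them only; others in the source may bear on it.

Values in an ADME assay on cells (spleen, Mus musculus, strain C57BL/6) for inhibition, read by flow cytometry and propidium iodide staining, with a stated time of 24 h, at 37 degrees C; a higher number here means that more compound is needed for the effect, a lower number that less compound is needed:
- Compound 1 `O=C(O)CCCCc1cn(CC(=O)NCc2ccccc2)nn1`: 1080 uM
- Compound 2 `CC(C)(C)OC(=O)NCc1cn(CC(=O)NCc2ccccc2)nn1`: > 2000 uM, a limit of the assay
- Compound 3 `O=C(Cn1cc(-c2cccc(F)c2)nn1)NCc1ccccc1`: not yet measured

Among the compounds with values here, compound 1 carries the only actual number in this short series. Compound 2 gives no number, only (the limit of > 2000 uM in this assay, at which 1 of the 2 values shown sits).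

Compound 3 departs from compound 1 at a single place, with 3-fluorophenyl in place of 4-carboxybutyl on an aromatic carbon. The incoming group brings an aromatic ring of carbon only, and the hydrogen-bond donor and acceptor counted for the outgoing group are gone.

Within the data shown here, one measured step bears on this, and only loosely: an at least 1.8-fold higher number from compound 1 to compound 2 (0.26 log units; that floor lies within the scatter). That step alters a group on the chain and gives a floor rather than a size. Among the measured compounds shown here, no measured compound carries an aromatic ring at this place.

On that evidence, no step beyond the scatter is expected in this assay, and any direction is only a slight lean towards a lower number. The expected step is a 1.4-fold lower number from compound 1 to compound 3 (0.13 log units; within the scatter). The estimate for compound 3 is 800 uM, with an expected range of 300 uM to 2000 uM.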

Compound 3, concentration for half-maximal effect: "non-toxic" (no number reported)
Compound 3: no number reported, so the estimate cannot be set against anything.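

In this assay compound 3 is reported only as "non-toxic", without a number, so no step can be read from it to compound 1 or compound 2. The compounds shown leave open the size and direction of any shift when 3-fluorophenyl replaces 4-carboxybutyl on the core of compound 1, which stands at 1080 uM.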